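The source may report more compounds than this note shows. Statements on the series, on what has been measured and on what is new or still open speak of the compounds shown alone.

Compound 1 `O=C(N[C@H]1CN(S(=O)(=O)c2ccccc2)C[C@@H]1C(=O)N[C@H]1CCCNC1)c1cc(-c2ccccc2)on1`: 15.6 L/kg
Compound 2 `Cc1nc(-c2cccc(C(F)(F)F)c2)sc1C(=O)N[C@H]1CN(S(=O)(=O)c2ccccc2)C[C@@H]1C(=O)N[C@H]1CCCNC1`: 5.5 L/kg

In an ADME assay on the whole organism (Canis lupus familiaris) for pharmacokinetics (on this read-out lower numbers stand for narrower distribution and higher numbers for wider distribution into tissues), compound 1 has the higher of the two numbers, a gap to compound 2 that lies beyond the usual scatter. Compound 3 `O=C(N[C@H]1CN(S(=O)(=O)c2ccccc2)C[C@@H]1C(=O)N[C@H]1CCCNC1)c1cc(-c2ccccc2Cl)on1` keeps the structure of compound 1 but turns phenyl to 2-chlorophenyl, with chloro in place of hydrogen on an aromatic carbon. Among the compounds with values here, no measured pair shows this change alone, so the expectation is tentative: no shift in this assay beyond the scatter. The expected change is a 1.1-fold lower number from compound 1 to compound 3 (0.05 log units; within the scatter). The estimated value for compound 3 is 14 L/kg, with an expected range from 7.5 L/kg to 24 L/kg.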

Compound 3, volume of distribution at steady state: 6.6 L/kg
Estimate against measurement, compound 3: 2.1-fold (0.33 log units) above, and the stated range ends above it.
By their numbers in this assay, from the lowest: compounds 2 and 3 (each within the scatter of the next); then compound 1.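

In this assay, within the data shown here, the change from phenyl to 2-chlorophenyl gives a 2.4-fold lower number from compound 1 to compound 3 (0.37 log units; beyond the scatter) and is the first single-place change in this set. It shows that this one added atom, on an aromatic carbon and ortho to a large group, can shift the read-out beyond the scatter. Nothing measured here says why the number falls.

From the compounds shown here alone, whether fluoro or methoxy in this same place would give a step of similar size stays open, as does the effect of chloro on another carbon of this ring. Among these compounds, this is also a single pair, so it sets no rule for other compounds.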